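The source may hold more compounds than are shown below. What is called first, only, known or untested is meant among the compounds shown, and "the series" means these compounds.

Among the measured compounds shown here, compound 1 `CCOC(=O)C1=C(C)N/C(=C/c2cc(C)n(-c3ccc(Br)cc3)c2C)C1=O` is the only member of this small set with a number in hand: in a physicochemical assay for lipophilicity, read by HPLC, at pH 7.4 (on this read-out higher numbers stand for higher lipophilicity and lower numbers for lower lipophilicity), compound 1 gives 3.4. Compound 2 `CCOC(=O)C1=C(C)N/C(=C/c2cc(C)n(-c3cccc(O)c3)c2C)C1=O` carries a 3-hydroxyphenyl group on the aromatic nitrogen of the shared core, and in this assay compound 2 gives "not determined" (no result reported), so there is no single number on which compound 2 stands. Compound 3 `CCOC(=O)C1=C(C)N/C(=C/c2cc(C)n(-c3cccnc3)c2C)C1=O` is the next member: pyridin-3-yl in place of 3-hydroxyphenyl on an aromatic nitrogen. For the measured compounds named here, with no measured pair of compounds differing in a single place, the size of the step cannot be read from anything here. On the groups involved, a small downward step in this assay is expected for compound 3 relative to compound 2, though it may well fall within the scatter of repeated measurements. Compound 3 is therefore estimated at 2.1, within a range from 1.5 to 2.7.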

Compound 3, distribution coefficient: 2.1
Beside the measured number, compound 3's estimate shows no gap at the digits printed; the measured number falls inside the stated range.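

In this assay, among the compounds shown here, the change from 4-bromophenyl to pyridin-3-yl on the aromatic nitrogen gives a number 1.30 log units lower from compound 1 to compound 3 (beyond the scatter) and so provides the first measured step at this position, showing that the read-out responds to what sits there. The step from compound 2 to compound 3 cannot be read: compound 2 has no number, and the 3-hydroxyphenyl group therefore stays unplaced. Nothing given here accounts for the size of the step.

From the compounds shown here alone, the step changes the bromine and the ring nitrogen together, so the share of each stays open, and a plain phenyl group would separate the two. Also open, going by these compounds, is where a carboxylic acid or an amine would fall in this assay on this aromatic nitrogen.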